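The source may report more compounds than this note shows. Statements on the series, on what has been measured and on what is new or still open speak of the compounds shown alone.

Of the compounds shown here, two have been measured in a functional assay on the whole organism (B cells) with Mus musculus as the target; a higher number here means a larger maximal response, a lower number a smaller maximal response. Compound 1 `C=CCn1c(=O)n(Cc2ccccc2)c2nc(N)nc(O)c21` gives 25% in this assay, while compound 2 `CC1OC(n2c(=O)n(C)c3c(O)nc(N)nc32)[C@H](O)[C@@H]1O` gives 0%. For the measured compounds named here, compound 2 therefore stands at the lowest of the two numbers, and the nearest compound, compound 1, lies higher by a gap that is beyond the scatter; no single-point step links these two structures, so only their two values can be compared.

Compound 3 `Cn1c(=O)n(C2OC(CI)[C@@H](O)[C@H]2O)c2nc(N)nc(O)c21` differs from compound 2 in one place: iodo in place of hydrogen on a saturated chain carbon bound to a saturated ring carbon. Cut one bond further out, the same difference reads methyl to iodomethyl. Going by the values given here, no measured pair shows what this change does in this assay, so the step from compound 2 to compound 3 is expected to be small, either direction, and likely none beyond the scatter, a number 5 percentage points higher from compound 2 to compound 3 (within the scatter). For compound 3 the expected maximal response in this assay is 5%, within a range of 0% to 20%.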

Compound 3, largest response reached (reported as maximal response), in percent of the reference or control that the assay uses: 32%
The estimate for compound 3 lay 27 percentage points below the measured number, outside the stated range (above it).
By their numbers in this assay, from the lowest: compound 2; then compounds 1 and 3 (each within the scatter of the next).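

In this assay, iodo in place of hydrogen on a saturated chain carbon bound to a saturated ring carbon gives a number 32 percentage points higher from compound 2 to compound 3 (beyond the scatter). For the compounds shown here, this is the first measured sign that this position matters in this assay: methyl to iodomethyl is the only difference between compound 2 (at 0%) and compound 3 (at 32%), so one added heavy atom separates no recorded response from a clear one. Nothing measured here bears on why this step occurs.

The compounds shown leave open whether the response is specific to iodo, or whether chloro, bromo or an amine on the same carbon would give a similar number. They also leave open whether the same change would have a comparable effect on a different core, such as that of compound 1.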